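The compounds below may be only part of what the source reports. "The series", "measured", "known", "first", "only" and "open" are said of these compounds alone.

Compound 1 `O=C(COc1ccc2cc(/C=C3/SC(=O)NC3=O)ccc2c1)Nc1cc(Cl)cc(C(F)(F)F)c1`: in an assay on isolated protein for inhibition of histone deacetylase 8 (Homo sapiens), with a stated time of 1 h (on this read-out lower numbers stand for stronger inhibition and higher numbers for weaker inhibition), compound 1 gives > 50000 nM, which is a limit of the assay and not a number.
Compound 2 `Cc1cccc(NC(=O)COc2ccc3cc(/C=C4/SC(=O)NC4=O)ccc3c2)n1`: in this assay compound 2 gives 7500 nM.
Compound 3 `O=C(COc1ccc2cc(/C=C3/SC(=O)NC3=O)ccc2c1)Nc1c(F)cc(F)cc1Br`: in this assay compound 3 gives > 50000 nM, again a limit of the assay.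

Compound 3 therefore stands at the upper edge of what the assay reports; the limit of > 50000 nM in this assay, at which 2 of the 3 values shown sit, marks where two of the three values sit, so there is no number for it, only a limit. Among the compounds with values here, the single readable step into compound 3 is an at least 6.6-fold higher number from compound 2 to compound 3 (0.82 log units; beyond the scatter); the step that the two limits leave unreadable from compound 1 to compound 3 cannot be sized, and an at least 6.6-fold lower number from compound 1 to compound 2 (0.82 log units; beyond the scatter) shows the 6-methylpyridin-2-yl compound apart from the two limits.

Compound 4 `COc1cccc(NC(=O)COc2ccc3cc(/C=C4/SC(=O)NC4=O)ccc3c2)c1` differs from compound 3 by 3-methoxyphenyl in place of 2-bromo-4,6-difluorophenyl on an amide-type nitrogen. The 3-methoxyphenyl group has no measured comparison in the series, so the expectation rests on compound 2 and compound 3 alone. A lower number is expected for compound 4 because an at least 6.6-fold higher number from compound 2 to compound 3 (0.82 log units; beyond the scatter) shows that replacing 2-bromo-4,6-difluorophenyl at the amide-type nitrogen can move the read-out by a modest step, though not every replacement does. In this assay compound 4 is expected at about 20000 nM, within 5000 nM to 60000 nM. The expected step is then an at least 2.5-fold lower number from compound 3 to compound 4 (0.39 log units; beyond the scatter), with a real chance that only a limit is returned.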

Compound 4, half-maximal inhibitory concentration: 7600 nM
The estimate for compound 4 lay 2.6-fold (0.42 log units) above the measured number; low and high end bracket the measured number.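

In this assay, 3-methoxyphenyl on the amide-type nitrogen restores a readable number, with an at least 6.5-fold lower number from compound 3 to compound 4 (0.81 log units; beyond the scatter) and an at least 6.5-fold lower number from compound 1 to compound 4 (0.81 log units; beyond the scatter). With a 1.0-fold higher number from compound 2 to compound 4 (0.01 log units; within the scatter), the 6-methylpyridin-2-yl and 3-methoxyphenyl groups cannot be told apart here, so a nitrogen in this aromatic ring is not required for a readable value at this place. The two compounds whose groups carry halogens, compound 1 and compound 3, remain limits of the assay and not numbers: the limit of > 50000 nM in this assay, at which 2 of the 4 values shown sit.

The compounds shown do not say whether the readable value of compound 4 comes from the methoxy group itself, or whether the unsubstituted phenyl group would also give a number. Going by these compounds, it also stays open whether an amine or a carboxylic acid on the aromatic ring at this nitrogen would take the read-out lower than the values that compound 2 and compound 4 share, or whether the halogens or the trifluoromethyl group alone are enough to reach the limit.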